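A few compounds are considered here, and "the series" means these few. Any claim that something is new, unique, unknown or untested is made for them only; others in the source may bear on it.

Series notes. Compound 1 `Cn1cc(-c2ccc3nnc(Sc4ccc5ncc(NC6CCOC6)cc5c4)n3c2)cn1` and compound 2 `Cn1cc(-c2ccc3nnc(Sc4ccc5ncc(NC6CCOCC6)cc5c4)n3c2)cn1` differ only in the ring attached to the nitrogen on the aromatic ring. In an ADME assay on cytosol from liver (strain IGS SD) for pharmacokinetics, with aldehyde oxidase 1 (Rattus norvegicus) as the target, read by LC-MS, with a stated time of 120 min, tested at 1 uM (on this read-out higher numbers stand for a longer-lived compound and lower numbers for a shorter-lived compound), compound 1 gives 1.35 h, and compound 2 gives 7.18 h; the step is a 5.3-fold higher number from compound 1 to compound 2 (0.73 log units; beyond the scatter). Going by the values given here, compound 2 thus stands highest of the two numbers measured so far in this assay, with compound 1 as its nearest neighbour and that gap beyond the scatter.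

Compound 3 `Cn1cc(-c2ccc3nnc(Sc4ccc5ncc(NC6COC6)cc5c4)n3c2)cn1` has not been measured in this assay; it differs from compound 2 by oxetan-3-yl in place of oxan-4-yl on a nitrogen on an aromatic ring. Among the compounds with values here, the only measured step bearing on this change is the one between compound 1 and compound 2, in which the larger ring carried the higher number, modestly but beyond the scatter. Shrinking the ring further, now to oxetan-3-yl, is expected to move the number back down, though this rests on a single step. The expected step is a 2.9-fold lower number from compound 2 to compound 3 (0.46 log units; beyond the scatter). Compound 3 is therefore estimated at 2.5 h in this assay, with a range from 0.8 h to 7 h.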

Compound 3, half-life: 2.15 h
The estimate for compound 3 lay 1.2-fold (0.07 log units) above the measured number; low and high end bracket the measured number.
By their numbers in this assay, from the lowest: compounds 1 and 3 (each within the scatter of the next); then compound 2.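

At this nitrogen on an aromatic ring, oxetan-3-yl in place of oxan-4-yl in this assay gives a 3.3-fold lower number from compound 2 to compound 3 (0.52 log units; beyond the scatter) and so does not keep the longer half-life of compound 2. Oxetan-3-yl in place of oxolan-3-yl gives a 1.6-fold higher number from compound 1 to compound 3 (0.20 log units; within the scatter) and so separates neither group from the other: across these three compounds the number does not follow ring size step by step, and only the oxan-4-yl of compound 2 stands apart. Nothing measured on hand bears on what sets the oxan-4-yl group apart.

Open, going by these compounds, is whether the ring oxygen matters, which a cyclohexyl group at the same nitrogen would test. Also open, on these data alone, is whether a ring is needed at all, or whether an open chain such as 2-methoxyethyl would give a similar half-life.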